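The compounds below may be only part of what the source reports. "The series", "measured", "known", "first", "only" and "open" are said of these compounds alone.

Measured so far in an in vitro functional assay on CHO/Galpha16 cells for antagonist activity at C-C chemokine receptor type 8 (Homo sapiens), read by FLIPR; a higher number here means a weaker inhibitor, a lower number a stronger inhibitor:
- compound 1 `CCCCc1ccc(C(=O)Nc2ccc(S(=O)(=O)NC3CCN(C(=O)CCC)CC3)c3ccccc23)cc1` gives 15.3 nM
- compound 2 `CCCC(=O)N1CCC(NS(=O)(=O)c2ccc(NC(=O)c3ccoc3)c3ccccc23)CC1` gives 1520 nM
- compound 3 `CCCC(=O)N1CCC(NS(=O)(=O)c2ccc(NC(=O)c3nccn3C)c3ccccc23)CC1` gives 20.4 nM

Compound 3 holds the second highest of the three numbers. Its nearest neighbour is compound 1, and the step of a 1.3-fold higher number from compound 1 to compound 3 (0.12 log units; within the scatter) is within the scatter, so the two cannot be ordered against each other. Its furthest neighbour is compound 2, separated by the step of a 75-fold lower number from compound 2 to compound 3 (1.87 log units; beyond the scatter).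

Compound 4 `CCCC(=O)N1CCC(NS(=O)(=O)c2ccc(NC(=O)c3ccccn3)c3ccccc23)CC1` is not yet measured. The change from compound 3 is pyridin-2-yl in place of 1-methyl-1H-imidazol-2-yl on a carbonyl carbon. All three measured steps vary the same group on the carbonyl carbon: a 99-fold higher number from compound 1 to compound 2 (2.00 log units; beyond the scatter) is large, a 75-fold lower number from compound 2 to compound 3 (1.87 log units; beyond the scatter) is large in the other direction, while a 1.3-fold higher number from compound 1 to compound 3 (0.12 log units; within the scatter) stays within the scatter. For the measured compounds named here, no measured step involves a pyridin-2-yl group, and no six-membered aromatic ring with one hetero atom has been tried at this position, so the expectation rests on the observation that both a 4-butylphenyl and a 1-methyl-1H-imidazol-2-yl give low numbers while only the furan-3-yl gives a high one.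

For compound 4 the step of a 1.5-fold higher number from compound 3 to compound 4 (0.17 log units; within the scatter) is expected to stay within the scatter, with a modest weakening the more likely direction if anything. Compound 4 is estimated at 30 nM in this assay, with a range from 8 nM to 120 nM.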

Compound 4, half-maximal inhibitory concentration: 41.7 nM
Compound 4: middle estimate off by 1.4-fold (0.14 log units), on the low side; the measured number falls inside the stated range.
By their numbers in this assay, from the lowest: compounds 1 and 3 (each within the scatter of the next); then compound 4; then compound 2.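

For the compounds shown here, the pyridin-2-yl group is the first six-membered aromatic ring with 1 hetero atom on this carbonyl carbon, and in this assay it sits far on the low side of furan-3-yl, with a 36-fold lower number from compound 2 to compound 4 (1.56 log units; beyond the scatter) as the large step. It can still be told apart from both low-number groups, with a 2.0-fold higher number from compound 3 to compound 4 (0.31 log units; beyond the scatter) and a 2.7-fold higher number from compound 1 to compound 4 (0.44 log units; beyond the scatter) as modest steps, the first of them only just beyond the scatter, so the low end at this position is not a single level. Furan-3-yl remains the only one of the four groups giving a number far above the others, and compound 2 against compound 3 shows that a five-membered aromatic ring with hetero atoms can fall at either end, so ring size alone does not sort the series.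

Open questions are whether pyridin-3-yl or pyridin-4-yl, an imidazol-2-yl ring without the methyl, or a non-aromatic group such as a simple amine or a plain butyl chain on this carbonyl carbon would keep the number low. No measurement at hand accounts for the ranking of these groups.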